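The compounds below may be only part of what the source reports. "The series", "measured", "known", "first", "only" and "open" are said of these compounds alone.

Measured so far in a functional assay on HCT-116 cells (Homo sapiens) for antiproliferative activity; a lower number here means a stronger inhibitor, a higher number a weaker inhibitor:
compound 1 `CNc1cc(-c2ccc3cnn(Cc4cc(OC)cc(OC)c4)c3c2)cn(C)c1=O`: 2900 nM
compound 2 `CNc1cc(-c2ccc3cnn(Cc4ccc(F)c(F)c4)c3c2)cn(C)c1=O`: 3000 nM

Among the compounds with values here, only two compounds have a number so far, and they cannot be told apart. In this assay, within the data shown here, compound 2 gives 3000 nM, level with its only neighbour within the usual scatter. The step between them, a 1.0-fold higher number from compound 1 to compound 2 (0.01 log units; within the scatter), exchanged the groups on the phenyl ring and left the number effectively unchanged.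

Compound 3 `CNc1cc(-c2ccc3cnn(Cc4ccc(F)c([N+](=O)[O-])c4)c3c2)cn(C)c1=O` keeps the shared core and alters one group of compound 2: nitro in place of fluoro on an aromatic carbon. In words, nitro takes the place of fluoro on an aromatic carbon, turning 3,4-difluorophenyl into 4-fluoro-3-nitrophenyl. The nitro group sits ortho to a fluoro group and meta to a large group.

Among the measured compounds shown here, no measured compound carries a nitro group, so there is no direct precedent. For the measured compounds named here, the only guide is the indirect one, a 1.0-fold higher number from compound 1 to compound 2 (0.01 log units; within the scatter), a change on the same phenyl ring that stayed within the scatter. On that thin evidence, no step beyond the scatter is expected, and the estimated result is a 1.1-fold lower number from compound 2 to compound 3 (0.03 log units; within the scatter). For compound 3 the expected value is 2800 nM, with an estimated range from 1000 nM to 8000 nM.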

Compound 3, half-maximal inhibitory concentration: 2600 nM
Compound 3: the middle estimate sits 1.1-fold (0.03 log units) above what was measured; the range from low to high includes it.
By their numbers in this assay, from the lowest: compounds 3, 1 and 2 (each within the scatter of the next).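

In this assay, nitro in place of fluoro on an aromatic carbon gives a 1.2-fold lower number from compound 2 to compound 3 (0.06 log units; within the scatter) and so stays within the scatter, even though three heavy atoms and two hydrogen-bond acceptors enter where one fluorine atom leaves. Compared with the 3,5-dimethoxyphenyl group, the 4-fluoro-3-nitrophenyl group gives a 1.1-fold lower number from compound 1 to compound 3 (0.05 log units; within the scatter) and also stays within the scatter, so the three phenyl groups shown on the shared core cannot be told apart in this assay, and this position has yet to show a step beyond the scatter. Nothing measured here explains why the number holds level across these groups.

Still open, as far as these compounds go, is whether any group on this phenyl ring can move the number beyond the scatter, and an amine or a carboxylic acid in the place of the nitro group would be a very different kind of test. Also open, from the compounds shown here alone, is what a longer chain between the phenyl ring and the aromatic nitrogen would do, since all three compounds share the same single saturated chain carbon there.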